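This account rests on a few compounds, and the source may have more. Where it says the series, first, only, none or still open, it means among the compounds named here.

Three compounds have been measured in a functional assay on OVCAR-5 cells (Homo sapiens) for cytotoxicity, read by sulforhodamine B assay, with a stated time of 48 h, tested at 0.01 uM; on this read-out higher numbers stand for a weaker effect at the one concentration tested and lower numbers for a stronger effect:
compound 1, `COc1cc(-c2cc(/C=C/C(=O)c3ccc(N)cc3)[nH]n2)cc(OC)c1OC`, giving 90%;
compound 2, `COc1ccc(-c2cc(/C=C/C(=O)c3ccc(N)cc3)[nH]n2)cc1OC`, giving 91%;
compound 3, `COc1cc(C(=O)/C=C/c2cc(-c3cc(OC)c(OC)c(OC)c3)n[nH]2)cc(OC)c1OC`, giving 97%.

Compound 4, `COc1ccc(-c2cc(/C=C/C(=O)c3cc(OC)c(OC)c(OC)c3)[nH]n2)cc1OC`, has not yet been measured in this assay. Between compound 1 and compound 2 the single change is hydrogen in place of methoxy on an aromatic carbon, and the measured step was a number 1 percentage points higher from compound 1 to compound 2 (within the scatter). From compound 3 to compound 4 the same change is made: hydrogen in place of methoxy on an aromatic carbon. The difference between the two cores is not broken down here. Among the compounds with values here, with only one measured instance of this change, the expectation rests on that step alone: the step expected is a number 1 percentage points lower from compound 3 to compound 4 (within the scatter), which follows from the step of a number 1 percentage points higher from compound 1 to compound 2 (within the scatter). On this basis compound 4 is estimated at 96%, most likely falling between 86% and 104%.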

Compound 4, a percentage reported as activity, at one concentration (the size of the read-out at that concentration, not a potency): 102%
For compound 4 the middle estimate is 6 percentage points below the measured one; low and high end bracket the measured number.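

In this assay, putting hydrogen in place of methoxy on an aromatic carbon gives a number 5 percentage points higher from compound 3 to compound 4 (within the scatter). Set beside the same change on the other core, the two steps agree: the same change on two cores in this assay, a number 1 percentage points higher (within the scatter) from compound 1 to compound 2 and a number 5 percentage points higher (within the scatter) from compound 3 to compound 4, 4 percentage points apart, within the scatter of two such steps. This shows that the change behaves alike on these two cores, but both steps are small enough to be measurement noise, so it shows no real effect of the change that carries over, and two pairs tested at one concentration cannot establish a rule for the series.

The compounds shown leave open what a different replacement for the methoxy, such as a hydroxyl group or a chlorine atom, would do. They also leave open whether the two steps would still agree at a higher concentration.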